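The compounds below may be only part of what the source reports. "The series", "measured", "known", "first", "only" and "open" are said of these compounds alone.

Measured compounds:
compound 1 `O=c1c2cnn(-c3ccc(F)cc3)c2ncn1CC1(O)CCN(Cc2ccccc2F)CC1`: 9800 nM in an assay on Sf21 cells for inhibition of ubiquitin carboxyl-terminal hydrolase 7 (Homo sapiens), read by spectrophotometry, with stated times of 30 min and 2 h; a higher number here means a weaker inhibitor, a lower number a stronger inhibitor
compound 2 `O=c1c2cnn(-c3ccc(F)cc3)c2ncn1CC1(O)CCN(Cc2ccccc2Cl)CC1`: 3400 nM in this assay
compound 3 `COC(=O)c1ccccc1CN1CCC(O)(Cn2cnc3c(cnn3-c3ccc(F)cc3)c2=O)CC1`: "not determined" (no result reported) in this assay

The series shares one core; the compounds differ in the group carried on the saturated chain carbon bound to the ring amine nitrogen. Compound 3 stands without a number in this assay: nothing about its potency is known, so it gives no anchor for the next step.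

Compound 4 `COC(=O)c1ccc(CN2CCC(O)(Cn3cnc4c(cnn4-c4ccc(F)cc4)c3=O)CC2)c(F)c1` differs from compound 3 by 2-fluoro-4-(methoxycarbonyl)phenyl in place of 2-(methoxycarbonyl)phenyl on a saturated chain carbon bound to an amine nitrogen in a ring. For the measured compounds named here, the one measured step, a 2.9-fold lower number from compound 1 to compound 2 (0.46 log units; beyond the scatter), concerns a halogen swap on that same aromatic ring and is not the same change as the one from compound 3 to compound 4; it only shows that the series as measured lies in the weak range and that a change on this ring can move the number modestly. Going by the values given here, with no value for compound 3 and no matching step, the expectation for compound 4 rests on the spread of compound 1 and compound 2 alone and carries a wide range.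

Compound 4 is estimated at 5000 nM in this assay, with a range from 1000 nM to 30000 nM.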

Compound 4, half-maximal inhibitory concentration: 800 nM
Estimate against measurement, compound 4: 6.3-fold (0.80 log units) above; the whole stated range lies above it.
By their numbers in this assay, from the lowest: compound 4; then compound 2; then compound 1.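

Methoxycarbonyl in place of hydrogen on an aromatic carbon gives a 12-fold lower number from compound 1 to compound 4 (1.09 log units; beyond the scatter) in this assay and is the first large step in the series, so this ring can carry more than a halogen swap and the number can move well out of the range set by the halogen-only compounds. The 2-fluoro-4-(methoxycarbonyl)phenyl group also outperforms 2-chlorophenyl, with a 4.3-fold lower number from compound 2 to compound 4 (0.63 log units; beyond the scatter) as a step beyond the scatter. No measurement shown accounts for these gains. Compound 3 has no value, so the steps to it cannot be read, and the separate contributions of the fluoro group and of where methoxycarbonyl sits remain unresolved. On these data alone, whether a carboxylic acid or a primary amide in place of methoxycarbonyl would hold the number also remains open.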